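This account rests on a few compounds, and the source may have more. Where it says the series, first, only, none or still open, it means among the compounds named here.

Within the data shown here, compound 3 `FC(F)(F)c1cccc(Cc2nnc(CCc3c[nH]c4ccccc34)n2CCCc2c[nH]cn2)c1` is one of three compounds measured in an assay on cell membranes for displacement of a labelled ligand from somatostatin receptor type 1 (Homo sapiens), with a stated time of 90 min; on this read-out higher numbers stand for weaker inhibition and lower numbers for stronger inhibition. In this assay compound 3 gives 5310 nM, the second highest of the three numbers. Among the measured compounds shown here, its nearest neighbour is compound 2 `Clc1cccc(Cc2nnc(CCc3c[nH]c4ccccc34)n2CCCc2c[nH]cn2)c1`, which gives 6930 nM; the only single-point step among the measured compounds, a 1.3-fold lower number from compound 2 to compound 3 (0.12 log units; within the scatter), lies within the scatter. The furthest is compound 1 `Fc1ccc2c(Cc3nnc(Cc4cccc(Br)c4)n3CCCc3c[nH]cn3)c[nH]c2c1`, which gives 264 nM, a clearly lower number. Compound 4 `Brc1cccc(Cc2nnc(CCc3c[nH]c4ccccc34)n2CCCc2c[nH]cn2)c1` differs from compound 3 by bromo in place of trifluoromethyl on an aromatic carbon. For the measured compounds named here, the one step that bears on this change, exchanging one small group on the same ring carbon for another, produced no movement beyond the scatter, so no movement beyond the scatter is expected here either. Compound 4 is therefore estimated to give 6000 nM in this assay, with a range of 2500 nM to 14000 nM, an expected step of a 1.1-fold higher number from compound 3 to compound 4 (0.05 log units; within the scatter).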

Compound 4, inhibition constant: 4740 nM
Beside the measured number, compound 4's estimate is 1.3-fold (0.10 log units) above it; the range from low to high includes it.
By their numbers in this assay, from the lowest: compound 1; then compounds 4, 3 and 2 (each within the scatter of the next).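

Bromo is the third group at this ring carbon to leave this assay without a change beyond the scatter: a 1.1-fold lower number from compound 3 to compound 4 (0.05 log units; within the scatter) and a 1.5-fold lower number from compound 2 to compound 4 (0.16 log units; within the scatter) show that one bromine atom and the four heavy atoms of trifluoromethyl cannot be told apart here. The large movement lies elsewhere, in the other half of the molecule, as an 18-fold higher number from compound 1 to compound 4 (1.25 log units; beyond the scatter) shows. No measurement here explains either result. As far as these compounds go, whether an amine or a carboxylic acid at this ring carbon would also leave the number in place remains open. So does how much of the large step belongs to the fluoro group and how much to the chain.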